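Nitro in place of fluoro on an aromatic carbon

The compounds below may be only part of what the source reports. "The series", "measured", "known", "first", "only" and "open" are said of these compounds alone.

In a functional assay on K562/A02 cells (Homo sapiens) for antiproliferative activity, read by MTT assay (a higher number here means a weaker inhibitor, a lower number a stronger inhibitor), compound 1 `O=C(CCCCCNC(=S)N/N=C(\c1ccccc1)c1ccccn1)NO` gives 2030 nM, compound 2 `Cc1ccc(/C(=N/NC(=S)NCCCCCC(=O)NO)c2ccccc2)cc1` gives 3150 nM, and compound 3 `O=C(CCCCCNC(=S)N/N=C(\c1ccccc1)c1ccccc1F)NO` gives 6010 nM. Compound 3 separates clearly only from compound 1: a 3.0-fold higher number from compound 1 to compound 3 (0.47 log units; beyond the scatter) is a modest step beyond the scatter, whereas a 1.9-fold higher number from compound 2 to compound 3 (0.28 log units; within the scatter) stays within it.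

The next compound is compound 4 `O=C(CCCCCNC(=S)N/N=C(\c1ccccc1)c1ccccc1[N+](=O)[O-])NO`. The change is nitro in place of fluoro on an aromatic carbon: 2-fluorophenyl becomes 2-nitrophenyl, with the nitro on an aromatic carbon, ortho to a large group.

Among the measured compounds shown here, no measured step replaces this fluoro directly, and no measured compound carries a nitro, so the evidence is indirect. The nearest guide is the set of swaps of the aromatic group on the carbon with a double bond to nitrogen. Of these, a 1.6-fold higher number from compound 1 to compound 2 (0.19 log units; within the scatter) lies within the scatter, as does a 1.9-fold higher number from compound 2 to compound 3 (0.28 log units; within the scatter), and only a 3.0-fold higher number from compound 1 to compound 3 (0.47 log units; beyond the scatter) exceeds it, and then only modestly. Those steps exchange whole groups, while this one alters a single substituent, so a large shift is not expected, and no direction is favoured with any confidence. The estimated step, a 1.2-fold lower number from compound 3 to compound 4 (0.08 log units; within the scatter), is expected to stay within the scatter. Compound 4 is estimated at 5000 nM, with an expected range of 2200 nM to 11000 nM.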

Compound 4, half-maximal inhibitory concentration: 1310 nM
For compound 4 the middle estimate is 3.8-fold (0.58 log units) above the measured one; the measured number lies below the stated range.
By their numbers in this assay, from the lowest: compounds 4, 1, 2 and 3 (each within the scatter of the next, the first and the last beyond it).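

In this assay, among the compounds shown here, this aromatic carbon, ortho to a large group, proves responsive to a change of one substituent: nitro in place of fluoro gives a step beyond the scatter (a 4.6-fold lower number from compound 3 to compound 4 (0.66 log units; beyond the scatter)), whereas the earlier comparisons exchanged whole aromatic groups. The 2-nitrophenyl group also separates from 4-methylphenyl (a 2.4-fold lower number from compound 2 to compound 4 (0.38 log units; beyond the scatter)) but not from pyridin-2-yl (a 1.5-fold lower number from compound 1 to compound 4 (0.19 log units; within the scatter)), so the 2-fluorophenyl compound no longer stands alone against pyridin-2-yl alone, and a substituted phenyl can match the pyridin-2-yl compound within the scatter. No measurement on these compounds accounts for the difference between fluoro and nitro at this place.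

The four compounds cannot show whether the lower number belongs to nitro specifically or would also appear with an amine, a nitrile or a methoxy group on the same aromatic carbon, nor how unsubstituted phenyl would compare with the 2-fluorophenyl and 2-nitrophenyl compounds. As far as these compounds go, whether the step from fluoro to nitro would hold with pyridin-2-yl in place of the unsubstituted phenyl, or with a longer chain leading to the hydroxamic acid, also remains open.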